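The compounds below may be only part of what the source reports. "The series", "measured", "known", "first", "only" and "open" are said of these compounds alone.

Working notes on the series in an ADME assay on HepG2 2.2.15 cells (Homo sapiens) for cytotoxicity; a lower number here means that less compound is tolerated, a higher number that more compound is tolerated. Compound 1 `O=C(Nc1ncc(Cc2ccc(Cl)cc2)s1)c1ccc(F)cc1F` is recorded in this assay as "not toxic" (no number reported), and compound 2 `Clc1ccc(C(Oc2ccc3cc(Br)ccc3c2)c2cnc(NCC3CCOCC3)s2)cc1` is likewise recorded as "not toxic" (no number reported). Compound 3 `CCCCCC(=O)Nc1ncc(C(Oc2ccc3cc(Br)ccc3c2)c2ccc(Cl)cc2)s1` reaches only a limit of the assay, > 50000 nM, so no single number stands for it. That entry is the limit of > 50000 nM in this assay, at which 1 of the 3 values shown sits, and none of the three compounds carries a plain value. The step under consideration leads to compound 4 `O=C(Nc1ncc(C(Oc2ccc3cc(Br)ccc3c2)c2ccc(Cl)cc2)s1)c1ccc(F)cc1F`, which differs from compound 3 by 2,4-difluorophenyl in place of pentyl on a carbonyl carbon. Compound 1 carries the same amide and is recorded in this assay as "not toxic" (no number reported). Among the measured compounds shown here, no measured step exists for comparison; the step from compound 3 to compound 4 in this assay is expected as a step that the limit leaves unreadable from compound 3 to compound 4, none beyond the scatter. Compound 4 is expected to give about 80000 nM, within a range of 30000 nM to 200000 nM, most probably again reported only as a limit.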

Compound 4, half-maximal cytotoxic concentration: "not toxic" (no number reported)
Compound 4: no number reported, so the estimate cannot be set against anything.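

Among the compounds shown here, no step from compound 3 to compound 4 can be read in this assay, as neither compound carries a plain value. The compounds shown leave open at what concentration, if any, cytotoxicity would appear for any of them.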